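The source may report more compounds than this note shows. Statements on the series, on what has been measured and on what is new or still open speak of the compounds shown alone.

Measured so far:
Compound 1 `Cc1ccccc1/C=N\NC(=S)N(Cc1ccccc1)Cc1ccccc1` — 167000 nM
Compound 2 `C/C(=N/NC(=S)N(Cc1ccccc1)Cc1ccccc1)c1ccccc1` — 167000 nM

In an ADME assay on Vero cells (Chlorocebus sabaeus) for cytotoxicity, read by MTT assay, with a stated time of 72 h (a higher number here means that more compound is tolerated, a lower number that less compound is tolerated), compound 1 gives 167000 nM. Compound 2 gives 167000 nM. Within the data shown here, the one measured step, no change at the digits printed from compound 1 to compound 2 (within the scatter), exchanged one group for another of equal size on the amide-type nitrogen without moving the read-out, so compound 2 stands level with compound 1.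

Compound 3 `Oc1ccccc1/C=N\NC(=S)N(Cc1ccccc1)Cc1ccccc1` differs from compound 2 in one place: a group of 9 heavy atoms (7 carbon, 1 nitrogen, 1 oxygen; one six-membered aromatic ring of carbon only) in place of a group of 9 heavy atoms (8 carbon, 1 nitrogen; one six-membered aromatic ring of carbon only), on an amide-type nitrogen. The group that enters carries one oxygen where the group that leaves carries a carbon.

Among the measured compounds shown here, only the step from compound 1 to compound 2 bears on this change, and it lies within the scatter. It concerns the same nitrogen, so no step beyond the scatter is expected in this assay here either. Compound 3 is therefore expected at about 167000 nM, between 80000 nM and 340000 nM, a step of no change at the digits printed from compound 2 to compound 3 (within the scatter) that is expected to stay within the scatter.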

Compound 3, half-maximal cytotoxic concentration: 166000 nM
The estimate for compound 3 lay 1.0-fold (0.00 log units) above the measured number; measured number inside the range.
By their numbers in this assay, from the lowest: compounds 3, 1 and 2 (each within the scatter of the next).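

In this assay, putting hydroxy in place of methyl on an aromatic carbon gives a 1.0-fold lower number from compound 1 to compound 3 (0.00 log units; within the scatter) and so adds a new kind of change to the series: the entering group counts 1 hydrogen-bond donor and 2 hydrogen-bond acceptors, against 0 and 1 for the group that leaves. The wider exchange on the amide-type nitrogen gives a 1.0-fold lower number from compound 2 to compound 3 (0.00 log units; within the scatter) and likewise leaves the read-out within the scatter, so none of the three compounds stands apart in how well it is tolerated. No supporting measurement bears on why these numbers stay level.

On these data alone, whether an amine or a carboxylic acid on that aromatic carbon would also leave the number level remains open. So does the effect of a longer chain in place of methyl.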